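4-Methyl-3-(trifluoromethyl)phenyl in Place of 4-Methoxyphenyl on the Sulfonyl Sulfur

The source may report more compounds than this note shows. Statements on the series, on what has been measured and on what is new or still open speak of the compounds shown alone.

Compound 1 `CC(C)(C)NCc1ccc2c(c1)CCC[C@H]2NC(=O)C[C@@H]1CCCCN1S(=O)(=O)c1ccccc1` gives 2400 nM in a functional assay for inhibition of B1 bradykinin receptor (Homo sapiens), read by calcium flux; a lower number here means a stronger inhibitor, a higher number a weaker inhibitor. Compound 2 `COc1ccc(S(=O)(=O)N2CCCC[C@H]2CC(=O)N[C@@H]2CCCc3cc(CNC(C)(C)C)ccc32)cc1` carries a methoxy where compound 1 has hydrogen. In this assay compound 2 gives 1400 nM. Going by the values given here, of the two numbers the one for compound 2 is the smaller, but a 1.7-fold lower number from compound 1 to compound 2 (0.23 log units; within the scatter) falls within the scatter, so the two compounds cannot be told apart on these data.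

Compound 3 `Cc1ccc(S(=O)(=O)N2CCCC[C@H]2CC(=O)N[C@@H]2CCCc3cc(CNC(C)(C)C)ccc32)cc1C(F)(F)F` differs from compound 2 in one place: 4-methyl-3-(trifluoromethyl)phenyl in place of 4-methoxyphenyl on a sulfonyl sulfur. Among the compounds with values here, the only measured step, a 1.7-fold lower number from compound 1 to compound 2 (0.23 log units; within the scatter), touches the same ring on the sulfonyl sulfur, yet it is a smaller change and stayed within the scatter; no step shows what a change of this extent does. The expectation is therefore no movement beyond the scatter, no change at the digits printed from compound 2 to compound 3 (within the scatter), with a wide range to reflect that uncertainty. Compound 3 is expected to give 1400 nM in this assay, somewhere between 350 nM and 5600 nM.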

Compound 3, half-maximal inhibitory concentration: 16 nM
Compound 3: the middle estimate sits 88-fold (1.94 log units) above what was measured, and the stated range ends above it.
By their numbers in this assay, from the lowest: compound 3; then compounds 2 and 1 (each within the scatter of the next).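

Going by these compounds alone, the aryl group on the sulfonyl sulfur proves to be a place where this assay can move far: 4-methyl-3-(trifluoromethyl)phenyl in place of 4-methoxyphenyl gives an 88-fold lower number from compound 2 to compound 3 (1.94 log units; beyond the scatter), whereas the only earlier change on this ring, methoxy for hydrogen, stayed within the scatter. Measured against the unsubstituted phenyl, the same group gives a 150-fold lower number from compound 1 to compound 3 (2.18 log units; beyond the scatter), so the ring's substituents matter at this position even though a methoxy alone showed no measurable effect. Nothing shown here accounts for the size of this step.

The new ring brings in methyl and trifluoromethyl together and loses the methoxy in the same step, so the compounds shown do not tell which of these changes carries the gain. From the compounds shown here alone, whether either group alone would suffice, or whether a chlorine atom or a nitrile could stand in for the trifluoromethyl, remains open.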